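The source may report more compounds than this note shows. Statements on the series, on what has been measured and on what is new or still open speak of the compounds shown alone.

The compounds here share one core, a fused ring system carrying two propyl chains, and differ in the group on an aromatic carbon of its five-membered ring. Compound 1 `CCCn1c(=O)c2nc(C3CCC(C(=O)O)CC3)[nH]c2n(CCC)c1=O` carries a cyclohexyl bearing a carboxylic acid; in a functional assay for antagonist activity at adenosine receptor A1 (Homo sapiens) (a lower number here means a stronger inhibitor, a higher number a weaker inhibitor), compound 1 gives 59 nM; 430 nM (2 entries), two entries that differ widely (the several entries of compound 1 in this assay, 59 nM; 430 nM (2 entries)). Compound 2 `CCCn1c(=O)c2nc(C3CCCC3C(=O)N(C)CCN(C)C)[nH]c2n(CCC)c1=O` carries a cyclopentyl with an amide side chain. In this assay compound 2 gives 53 nM; > 3000 nM (2 entries), two entries that differ widely (the several entries of compound 2 in this assay, 53 nM; > 3000 nM (2 entries)). Among the measured compounds shown here, compound 3 `CCCn1c(=O)c2nc(C3CCC3C(=O)O)[nH]c2n(CCC)c1=O` carries a 2-carboxycyclobutyl and in this assay compound 3 gives 660 nM; this is its only number, two further entries having yielded no single number. That number lies well above the lower entries of compound 1 and compound 2 and close to the higher entry of compound 1.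

Compound 4 `CCCn1c(=O)c2nc(NC3CCCCC3)[nH]c2n(CCC)c1=O` is not yet measured. It differs from compound 3 in one place: cyclohexylamino in place of 2-carboxycyclobutyl on an aromatic carbon. For the measured compounds named here, no measured pair shows this change, so the direction rests on the change alone. Compound 4 is expected to be a somewhat stronger inhibitor, the estimated step of an 8.3-fold lower number from compound 3 to compound 4 (0.92 log units; beyond the scatter) pointing toward lower values, with a broad range because repeat entries scatter widely for compound 1 the several entries of compound 1 in this assay, 59 nM; 430 nM (2 entries) and compound 2 (the several entries of compound 2 in this assay, 53 nM; > 3000 nM (2 entries)). For compound 4 the estimate in this assay is 80 nM, from 15 nM to 400 nM.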

Compound 4, inhibition constant: 14 nM
Estimate against measurement, compound 4: 5.7-fold (0.76 log units) above; the measured number lies below the stated range.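

Among the compounds shown here, replacing the 2-carboxycyclobutyl with cyclohexylamino on this aromatic carbon of the five-membered ring gives, in this assay, a 47-fold lower number from compound 3 to compound 4 (1.67 log units; beyond the scatter), the first readable step here, and it shows that a single change at this position can shift the number by a large margin. Compound 1 is hard to set firmly against compound 4, because its two entries disagree widely: the several entries of compound 1 in this assay, 59 nM; 430 nM (2 entries). Compound 2 is equally uncertain, and one of its entries is a limit of the assay and not a number: the several entries of compound 2 in this assay, 53 nM; > 3000 nM (2 entries).

This one step removes the carboxylic acid, enlarges the ring from four members to six and adds a nitrogen link to the core all at once, and the compounds shown do not tell which of these changes accounts for the lower number. A cyclobutylamino group would keep the small ring with the nitrogen link, and a plain cyclohexyl group would keep the large ring without the nitrogen, so these two groups on the same carbon would begin to separate the effects.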